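Extending the amide side chain in a dihydrofolate reductase inhibitor

This account rests on a few compounds, and the source may have more. Where it says the series, first, only, none or still open, it means among the compounds named here.

Measured compounds:
Compound 1 `CC1(C)N=C(N)N=C(N)N1c1ccc(OCCCNC(=O)c2ccc(S(=O)(=O)F)cc2)c(Cl)c1`: 7.34
Compound 2 `CC1(C)N=C(N)N=C(N)N1c1ccc(OCc2c(Cl)cccc2S(=O)(=O)F)c(Cl)c1`: 7.72

In an assay on isolated protein for inhibition of Dihydrofolate reductase (Mus musculus) (a lower number here means a less potent compound, a higher number a more potent compound, by a factor of ten per unit of this negative logarithm), compound 1 gives 7.34, the lower of the two numbers shown. Compound 2 gives 7.72 in this assay, a value that lies beyond the usual scatter above compound 1, but the two compounds differ in more than one place, so no single change can be held responsible.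

Compound 3 `Cc1cc(NC(=O)NCCCOc2ccc(N3C(N)=NC(N)=NC3(C)C)cc2Cl)ccc1S(=O)(=O)F` is an unmeasured analogue of compound 1. The change is a group of 12 heavy atoms (7 carbon, 1 nitrogen, 2 oxygen, 1 fluorine, 1 sulfur; one six-membered aromatic ring of carbon only) in place of a group of 10 heavy atoms (6 carbon, 2 oxygen, 1 fluorine, 1 sulfur; one six-membered aromatic ring of carbon only), on a carbonyl carbon. The shared core, the chloro-substituted ring and the three-carbon linker are kept; only the group on the carbonyl carbon is exchanged, with one hydrogen-bond donor added.

Going by the values given here, no measured pair isolates such a change, so the expected step is small, possibly none beyond the scatter. Compound 3 is estimated at 7.45 (range 6.85 to 8.05), a step of a number 0.11 log units higher from compound 1 to compound 3 (within the scatter) from compound 1.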

Compound 3, logarithm of the reciprocal of the active concentration, log(1/C): 8.06
For compound 3 the middle estimate is 0.61 log units below the measured one; the whole stated range lies below it.
By their numbers in this assay, from the lowest: compound 1; then compound 2; then compound 3.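

In this assay, exchanging the 4-(fluorosulfonyl)phenyl group on the carbonyl carbon for the larger group of compound 3 gives a number 0.72 log units higher from compound 1 to compound 3 (beyond the scatter). This shows that the position is not indifferent to what sits on it: a change here can move the number beyond the scatter, and a group with a hydrogen-bond donor is accepted with no loss. No measurement shown here explains the gain.

The entering group differs from the leaving one in more than one respect, so these compounds cannot say whether the added nitrogen or the added carbon accounts for the step. A plain 4-(fluorosulfonyl)anilino group, with the nitrogen but without the added carbon, would separate the two, while a carboxylic acid in place of the fluorosulfonyl group would test that part of the group.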